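From cyclohexylamino to pentyloxy on the shared core

The source may hold more compounds than are shown below. What is called first, only, known or untested is meant among the compounds shown, and "the series" means these compounds.

Three compounds were measured in an ADME assay on BCBL1 cells (Homo sapiens) for cytotoxicity, with a stated time of 7 days (a higher number here means that more compound is tolerated, a lower number that less compound is tolerated), with these results
- Compound 1 `CC(C)Nc1nc(N)nc2c1ncn2/C=C1/CC1(CO)CO` gives > 20000 nM as a limit
- Compound 2 `Nc1nc(NC2CC2)c2ncn(/C=C3/CC3(CO)CO)c2n1` gives 71500 nM as a number
- Compound 3 `Nc1nc(NC2CCCCC2)c2ncn(/C=C3/CC3(CO)CO)c2n1` gives > 20000 nM as a limit

Compound 3 is known only as a limit, one it shares with compound 1 (the limit of > 20000 nM in this assay, at which 2 of the 3 values shown sit). Compound 4 `CCCCCOc1nc(N)nc2c1ncn2/C=C1/CC1(CO)CO` carries pentyloxy in place of cyclohexylamino (pentyloxy in place of cyclohexylamino on an aromatic carbon). The measured steps that bear on this change only swap the group on the nitrogen, and none can be sized (a step that the two limits leave unreadable from compound 1 to compound 3; a step that the limit leaves unreadable from compound 2 to compound 3). No direction can therefore be expected, and the estimated step is a step that the limit leaves unreadable from compound 3 to compound 4 at most a modest one. Going by the values given here, the only number comes from compound 2 at 71500 nM and the expectation leans on it. Compound 4 is estimated at 40000 nM with a range from 15000 nM to 100000 nM. Once measured, compound 4 may give only a limit.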

Compound 4, half-maximal cytotoxic concentration: > 20000 nM
Compound 4: only a limit was reported (the forecaster's own chance of this, stated with the estimate: 55%); the middle value is on the limit's open side.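

In this assay, going by these compounds alone, compound 4 gives > 20000 nM, which is a limit, so no step linking it to compound 1, compound 2 or compound 3 can be read: the limit of > 20000 nM in this assay, at which 3 of the 4 values shown sit. On these data alone, how far pentyloxy and these amino groups differ on the shared core stays open.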